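Oxygen substituents on the shared core: compound 2 to compound 3

The source may hold more compounds than are shown below. What is called first, only, known or untested is meant among the compounds shown, and "the series" means these compounds.

- compound 1 `Cc1c(C)c2c(c(C)c1O)CCC(C)(/C=[N+](\[O-])C1CC1)O2`: 6000 nM
- compound 2 `COc1c(C)c(C)c2c(c1C)CCC(C)(/C=[N+](\[O-])C1CC1)O2`: 296000 nM

In a functional assay for inhibition, with Rattus norvegicus as the target (a lower number here means a stronger inhibitor, a higher number a weaker inhibitor), compound 2 has the higher number of the two, at 296000 nM. Compound 3 `CC(=O)Oc1c(C)c(C)c2c(c1C)CCC(C)(/C=[N+](\[O-])C1CC1)O2` carries acetyl in place of methyl on an oxygen on an aromatic ring. Going by the values given here, the only measured step at that oxygen is a 49-fold higher number from compound 1 to compound 2 (1.69 log units; beyond the scatter), which is large and beyond the scatter. No acetyl at that oxygen has been measured, so this step bears on the change only indirectly. Expected here is a 12-fold lower number from compound 2 to compound 3 (1.07 log units; beyond the scatter), which would undo only part of that measured step. For compound 3 the estimated value is 25000 nM, with an expected range of 5000 nM to 150000 nM.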

Compound 3, half-maximal inhibitory concentration: 117000 nM
Compound 3: middle estimate off by 4.7-fold (0.67 log units), on the low side; the measured number falls inside the stated range.
By their numbers in this assay, from the lowest: compound 1; then compound 3; then compound 2.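

In this assay the acetyl ester on this aromatic oxygen gives back only a small part of what the methyl ether loses (a 2.5-fold lower number from compound 2 to compound 3 (0.40 log units; beyond the scatter)), while the distance to the free hydroxyl stays large (a 20-fold higher number from compound 1 to compound 3 (1.29 log units; beyond the scatter)). Both capped forms therefore sit on the weak side of compound 1, and the choice of cap still shifts the number beyond the scatter. Nothing at hand gives a reason for the gap between methoxy and acetoxy.

Open, from the compounds shown here alone, is whether a larger acyl group such as benzoyl at this oxygen stays near compound 3. Also open, going by these compounds, is whether a longer ether such as ethoxy falls near compound 2.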